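The source may report more compounds than this note shows. Statements on the series, on what has been measured and on what is new or still open speak of the compounds shown alone.

Compound 1 `S=c1[nH]nc(Cc2ccc(Cl)cc2Oc2ccccc2Cl)[nH]1` and compound 2 `CCSc1nnc(Cc2ccc(Cl)cc2Oc2ccccc2Cl)[nH]1` share one core and differ only in the five-membered ring carried on a saturated chain carbon bound to an aromatic carbon. In a functional assay on the whole organism (strain NMRI) with Mus musculus as the target, with a stated time of 60 min, at a dose of 5 mg/kg by the intraperitoneal route (on this read-out lower numbers stand for a weaker effect and higher numbers for a stronger effect at the one dose given), compound 1 gives 124%. In this assay compound 2 gives 134%. Among the compounds with values here, the step of a number 10 percentage points higher from compound 1 to compound 2 (within the scatter) is the only measured step. The two numbers cannot be told apart: compound 2 stands on the same footing as compound 1.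

Compound 3 `Nc1nnc(Cc2ccc(Cl)cc2Oc2ccccc2Cl)o1` is not yet measured. It differs from compound 2 at the same place, (a group of 6 heavy atoms (2 carbon, 3 nitrogen, 1 oxygen; one five-membered aromatic ring with 3 hetero atoms) in place of a group of 8 heavy atoms (4 carbon, 3 nitrogen, 1 sulfur; one five-membered aromatic ring with 3 hetero atoms), on a saturated chain carbon bound to an aromatic carbon), again an exchange of one five-membered aromatic ring with three hetero atoms for another.

Within the data shown here, the single step that bears on this change, a number 10 percentage points higher from compound 1 to compound 2 (within the scatter), stayed within the scatter when the ring at that position was altered. On that basis no movement beyond the scatter is expected, and the estimated step is a number 9 percentage points lower from compound 2 to compound 3 (within the scatter). Compound 3 is therefore expected to give about 125% in this assay, with a range from 95% to 155%.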

Compound 3, a percentage reported as activity, at one dose (the size of the read-out at that dose, not a potency): 125%
The estimate for compound 3 equals the measured number at the digits printed, and the stated range covers the measured number.
By their numbers in this assay, from the lowest: compounds 1, 3 and 2 (each within the scatter of the next).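

The step of a number 9 percentage points lower from compound 2 to compound 3 (within the scatter) and the step of a number 1 percentage points higher from compound 1 to compound 3 (within the scatter) show that 5-amino-1,3,4-oxadiazol-2-yl can stand on the saturated chain carbon bound to an aromatic carbon in this assay with no difference that can be told from the scatter. Both earlier compounds carried sulfur in this group and compound 3 carries oxygen instead, so among the three compounds shown the read-out at this one dose does not rest on the presence of sulfur. The three different groups at this place therefore stand on the same footing, and no measured finding is available that would explain this.

The compounds shown leave open whether a group other than a five-membered aromatic ring with three hetero atoms, such as a carboxylic acid or a simple amine, would hold the read-out at this place. They also leave open whether a longer chain on the sulfur of compound 2 would move the number beyond the scatter, and whether the three compounds would still stand together at other doses.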